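The compounds below may be only part of what the source reports. "The series", "measured", "known", "first", "only" and "open" are said of these compounds alone.

Compound 1 `COC(=O)CC1c2ccccc2N=C(N2CCN(C)CC2)N1c1ccccc1`: 15%
Compound 2 `COC(=O)CC1c2ccccc2N=C(N2CCOCC2)N1C(C)C`: about 0%

In a functional assay on cells (Oocyte) for inhibition of Voltage-dependent T-type calcium channel subunit alpha-1H (Homo sapiens), tested at 100 uM (on this read-out lower numbers stand for less inhibition and higher numbers for more inhibition at the one concentration tested (going by the name of the read-out)), compound 1 gives 15%, while compound 2 gives about 0%. Compound 2 thus stands lowest of the two numbers; its nearest neighbour, compound 1, lies higher by an amount beyond the usual scatter, though the two compounds differ in more than one place, so no single change can be credited with that gap.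

The step now followed leads from compound 2 to compound 3 `COC(=O)CC1c2ccccc2N=C(N2CCN(C)CC2)N1C(C)C`. The change is 4-methylpiperazin-1-yl in place of morpholin-4-yl on a carbon with a double bond to nitrogen. Compound 1 carries the same 4-methylpiperazin-1-yl group and shows some inhibition, which suggests the step from compound 2 to compound 3 may bring a small rise, but one that could still fall within the scatter. The expected step is a number 8 percentage points higher from compound 2 to compound 3 (within the scatter). For compound 3 the estimate is 8%, with a range from 0% to 25%.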

Compound 3, a percentage reported as inhibition, at one concentration (the size of the read-out at that concentration, not a potency): about 0%
Compound 3: middle estimate off by 8 percentage points, on the high side; measured number inside the range.
By their numbers in this assay, from the lowest: compounds 2 and 3 (each within the scatter of the next); then compound 1.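

In this assay, with an isopropyl group held on the amine nitrogen in a ring, replacing morpholin-4-yl with 4-methylpiperazin-1-yl gives no change at the digits printed from compound 2 to compound 3 (within the scatter), so this pair shows no gain from that exchange. With 4-methylpiperazin-1-yl held constant, isopropyl in place of phenyl gives a number 15 percentage points lower from compound 1 to compound 3 (beyond the scatter), which ties the inhibition of compound 1 in this pair to the phenyl group and not to 4-methylpiperazin-1-yl alone. Nothing measured here offers an explanation for either step.

On these data alone, whether morpholin-4-yl would give the same result alongside phenyl remains open. So does the effect of a benzyl group or a longer alkyl chain on that nitrogen, or of a carboxylic acid in place of the methyl ester.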